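A Hydroxy Group Where Fluorine Gave Only a Limit

The compounds below may be only part of what the source reports. "The series", "measured", "known", "first", "only" and "open" are said of these compounds alone.

Of the compounds shown here, three from one series have been measured in an ADME assay on HaCaT cells (Homo sapiens) for antiproliferative activity, read by MTT assay, with a stated time of 48 h; a lower number here means a stronger inhibitor, a higher number a weaker inhibitor. Compound 1 `O=C(/C=C\Nc1ccc(F)cc1)c1cn(-c2ccccc2)nc1-c1ccccc1` gives 34200 nM in this assay. Compound 2 `O=C(/C=C\Nc1ccc(Cl)cc1)c1cn(-c2ccccc2)nc1-c1ccccc1` gives 28400 nM. Compound 3 `O=C(/C=C\Nc1ccc(F)cc1)c1cn(-c2ccccc2)nc1-c1ccc(F)cc1` gives > 50000 nM, which is a limit of this assay and not a number. Two single changes connect the measured compounds: a 1.2-fold lower number from compound 1 to compound 2 (0.08 log units; within the scatter); and an at least 1.4-fold higher number from compound 1 to compound 3 (0.16 log units; that floor lies within the scatter). Compound 3 thus stands at the limit of > 50000 nM in this assay, at which 1 of the 3 values shown sits, so no firm figure marks it. Compound 4 `O=C(/C=C\Nc1ccc(O)cc1)c1cn(-c2ccccc2)nc1-c1ccc(F)cc1` differs from compound 3 in one place: hydroxy in place of fluoro on an aromatic carbon. For the measured compounds named here, no measured step swaps fluoro for hydroxy, so the two steps seen are only a loose guide, and both of them stayed within the scatter. A step of similar size is therefore expected here, with no clear direction: a number no higher from compound 3 to compound 4 (the limit leaves the size open). For compound 4 the estimate in this assay is 50000 nM, spanning 25000 nM to 100000 nM, with a fair chance that the assay again reports only a limit.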

Compound 4, half-maximal inhibitory concentration: 16300 nM
Beside the measured number, compound 4's estimate is 3.1-fold (0.49 log units) above it; the measured number lies below the stated range.
By their numbers in this assay, from the lowest: compounds 4, 2 and 1 (each within the scatter of the next, the first and the last beyond it). At a limit, above all of these: compound 3.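

Hydroxy in place of fluoro gives an at least 3.0-fold lower number from compound 3 to compound 4 (0.48 log units; beyond the scatter) in this assay, so this position can respond to more than the swap between halogens, which gave a 1.2-fold lower number from compound 1 to compound 2 (0.08 log units; within the scatter). The entering hydroxy carries a hydrogen-bond donor and a hydrogen-bond acceptor that fluoro lacks, but this single pair cannot show whether they account for the step. The true size of the step stays unknown because compound 3 gives only a limit and not a number: the limit of > 50000 nM in this assay, at which 1 of the 4 values shown sits.

The compounds shown leave open whether a methoxy group or an amine at this position would act as hydroxy does. They also leave open whether hydroxy would give a similar step on the core of compound 1, where a firm number is available for comparison.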